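The source may report more compounds than this note shows. Statements on the series, on what has been measured and on what is new or still open speak of the compounds shown alone.

In a functional assay on A20 cells (Mus musculus) for inhibition, with stated times of 1 h, 16 h and 24 h (a higher number here means a weaker inhibitor, a lower number a stronger inhibitor), compound 1 `N#CC1(NC(=O)[C@@H]2C[C@@H](S(=O)(=O)c3ccccc3)C[C@H]2C(=O)N2CCS(=O)(=O)CC2)CC1` gives 816 nM and compound 2 `N#CC1(NC(=O)[C@@H]2C[C@@H](S(=O)(=O)c3ccccc3)C[C@H]2C(=O)Nc2ccc(F)cc2)CC1` gives 391 nM as the lower of the two numbers, which makes compound 2 the stronger inhibitor so far. Compound 3 `N#CC1(NC(=O)[C@@H]2C[C@@H](S(=O)(=O)c3ccccc3)C[C@H]2C(=O)N2CCC2)CC1` has not been measured yet. It keeps the shared core and differs from compound 2 in one place, on a carbonyl carbon. The change there is azetidin-1-yl in place of (4-fluorophenyl)amino on a carbonyl carbon and, in words, azetidin-1-yl takes the place of (4-fluorophenyl)amino. Among the compounds with values here, only one measured step touches this place. That step, a 2.1-fold lower number from compound 1 to compound 2 (0.32 log units; beyond the scatter) in size, is modest and came with (4-fluorophenyl)amino entering in place of 1,1-dioxothiomorpholin-4-yl. Compound 3 gives up that same (4-fluorophenyl)amino, so a modest move towards a higher number, and so a weaker inhibitor, is expected. Within the data shown here, one step is thin evidence, however, and no measurement yet shows what azetidin-1-yl does. The estimate therefore means a 1.7-fold higher number from compound 2 to compound 3 (0.22 log units; within the scatter) as the expected move. For compound 3 the expected value is 650 nM with 270 nM to 1500 nM as its estimated range.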

Compound 3, half-maximal inhibitory concentration: 44 nM
Compound 3: the middle estimate sits 15-fold (1.17 log units) above what was measured; measured number outside the range, below it.
By their numbers in this assay, from the lowest: compound 3; then compound 2; then compound 1.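

Within the data shown here, changing the group on this carbonyl carbon can shift the number much further than the earlier step showed: azetidin-1-yl in place of (4-fluorophenyl)amino gives an 8.9-fold lower number from compound 2 to compound 3 (0.95 log units; beyond the scatter) in this assay and this exceeds the only earlier step at this position. Azetidin-1-yl in place of 1,1-dioxothiomorpholin-4-yl gives a 19-fold lower number from compound 1 to compound 3 (1.27 log units; beyond the scatter) as the largest step in this set, and compound 3 therefore has the lowest number of the three, showing that neither the six-membered aromatic ring nor the hydrogen-bond donor of compound 2 is needed for a stronger inhibitor in this series. No outside information on these compounds accounts for the gain, so the result stands as an observation only.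

Compound 2 and compound 3 differ in ring size, aromatic character and hydrogen-bond donor count all at once, so the compounds shown cannot say which of these differences goes with the lower number. Going by these compounds, it also remains open whether the gain is particular to azetidin-1-yl or would extend to a slightly larger pyrrolidin-1-yl ring or to an open-chain dimethylamino group at the same carbonyl carbon.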